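Imidazole substituent swap: vinyl for isopropyl

The source may hold more compounds than are shown below. What is called first, only, known or untested is meant among the compounds shown, and "the series" means these compounds.

Measured so far:
compound 1 `CNC(=O)[C@@H](c1ccccc1)N1CCn2c(CC3CC3)nc(Cl)c2[C@@H]1CCc1ccc(C(F)(F)F)cc1` — 35 nM
compound 2 `CCc1nc(C(F)(F)F)c2n1CCN([C@@H](C(=O)NC)c1ccccc1)[C@H]2CCc1ccc(C(F)(F)F)cc1` — 11 nM
compound 3 `CCc1nc(C(C)C)c2n1CCN([C@@H](C(=O)NC)c1ccccc1)C2CCc1ccc(C(F)(F)F)cc1` — 2900 nM

In a functional assay on CHO cells for antagonist activity at Orexin receptor type 2 (Homo sapiens), read by FLIPR and calcium flux (on this read-out lower numbers stand for stronger inhibition and higher numbers for weaker inhibition), compound 3 stands highest of the three numbers; compound 1 sits closest to it and compound 2 furthest, both separated from compound 3 by gaps beyond the scatter. Compound 4 `C=Cc1nc(CC)n2c1C(CCc1ccc(C(F)(F)F)cc1)N([C@@H](C(=O)NC)c1ccccc1)CC2` is not yet measured and differs from compound 3 in one place: vinyl in place of isopropyl on an aromatic carbon. Among the compounds with values here, no measured pair follows this change. Compound 1, which carries a different group at this same place, gives 35 nM, and compound 2, which also carries a different group there, gives 11 nM. On that basis compound 4 is expected to move toward a lower number, by a step of a 5.8-fold lower number from compound 3 to compound 4 (0.76 log units; beyond the scatter). The estimate for compound 4 in this assay is 500 nM, with a range from 80 nM to 3000 nM.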

Compound 4, half-maximal inhibitory concentration: 23 nM
Compound 4: middle estimate off by 22-fold (1.34 log units), on the high side; the measured number lies below the stated range.
By their numbers in this assay, from the lowest: compound 2; then compounds 4 and 1 (each within the scatter of the next); then compound 3.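

In this assay, within the data shown here, vinyl in place of isopropyl gives a 130-fold lower number from compound 3 to compound 4 (2.10 log units; beyond the scatter), the only single-place step so far. Compound 3 and compound 4 share everything else, so the high number of compound 3 traces to the isopropyl on this aromatic carbon, and the position tolerates very little change without a large shift in the read-out. Nothing measured here explains the size of this step.

On these data alone, whether the double bond or the loss of the branch carries the step stays open. A methyl, a cyclopropyl or a nitrile on this carbon would test that.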